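A few compounds are considered here, and "the series" means these few. Any claim that something is new, unique, unknown or untested is made for them only; others in the source may bear on it.

Compound 1 `Cc1ccc(N2CCN(C(=S)SCc3ccc4nc(N)nc(N)c4c3)CC2)c(C)c1`: 2970 nM
Compound 2 `Nc1nc(N)c2cc(CSC(=S)N3CCN(c4ccc(F)cc4)CC3)ccc2n1`: 2050 nM

Among the measured compounds shown here, in a functional assay on HT-29 cells (Homo sapiens) for antiproliferative activity, read by MTT assay, with a stated time of 72 h (on this read-out lower numbers stand for stronger inhibition and higher numbers for weaker inhibition), compound 2 gives 2050 nM, which cannot be told apart from the only other measured number. Compound 3 `Nc1nc(N)c2cc(CSC(=S)N3CCN(c4ccc([N+](=O)[O-])cc4)CC3)ccc2n1` differs from it by one change, nitro in place of fluoro on an aromatic carbon, para to a large group. For the measured compounds named here, only one measured step bears on this, a 1.4-fold lower number from compound 1 to compound 2 (0.16 log units; within the scatter), and it swaps the whole aryl group on the amine nitrogen in a ring. Going by the values given here, with that as the sole guide, no shift beyond the scatter is expected, and no direction can be favoured. The expected change is a 1.1-fold higher number from compound 2 to compound 3 (0.03 log units; within the scatter). The estimate for compound 3 is 2200 nM, with an expected range of 900 nM to 5000 nM.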

Compound 3, half-maximal inhibitory concentration: 3320 nM
The estimate for compound 3 lay 1.5-fold (0.18 log units) below the measured number; the range from low to high includes it.
By their numbers in this assay, from the lowest: compounds 2, 1 and 3 (each within the scatter of the next).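

In this assay nitro in place of fluoro on an aromatic carbon, para to a large group, gives a 1.6-fold higher number from compound 2 to compound 3 (0.21 log units; within the scatter) and so adds two hydrogen-bond acceptors and more heavy atoms at this position without a shift beyond the scatter. The swap of the whole aryl group on the amine nitrogen in a ring reads the same, with a 1.1-fold higher number from compound 1 to compound 3 (0.05 log units; within the scatter), so the three aryl groups cannot be told apart here. Nothing at hand offers an explanation for these numbers. Going by these compounds, whether an amine or a carboxylic acid at this position would move the number beyond the scatter stays open.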